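One Methoxy Group, Two Cores, One Expected Step

The source may hold more compounds than are shown below. What is called first, only, known or untested is meant among the compounds shown, and "the series" means these compounds.

Compound 1 `COc1ccc(C(=O)Nc2nc(-c3cc(OC)c(OC)c(OC)c3)cs2)cc1OC` in a functional assay on MDA-MB-231 cells (Homo sapiens), read by microscopy and transwell migration, with a stated time of 24 h (on this read-out lower numbers stand for stronger inhibition and higher numbers for weaker inhibition), gives > 25000 nM, which is a limit of the assay rather than a number.
Compound 2 `COc1cccc(C(=O)Nc2nc(-c3cc(OC)c(OC)c(OC)c3)cs2)c1` gives 14000 nM.
Compound 3 `COc1cc(-c2cs/c(=N\C(=O)c3ccccc3)n2C)cc(OC)c1OC` gives 1070 nM.

Compound 3 stands lowest of the two numbers, and its gap to compound 2 lies beyond the scatter. How the core of compound 3 differs from the core of compound 2 is not broken down here.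

One change is shown twice. From compound 2 to compound 1 it reads (methoxy in place of hydrogen on an aromatic carbon), and that step gave an at least 1.7-fold higher number from compound 2 to compound 1 (0.25 log units; that floor lies within the scatter); note (the limit of > 25000 nM in this assay, at which 1 of the 3 values shown sits). The same kind of change leads from compound 3 to the unmeasured compound 4 `COc1ccc(C(=O)/N=c2\scc(-c3cc(OC)c(OC)c(OC)c3)n2C)cc1`: methoxy in place of hydrogen on an aromatic carbon. The two places are not identical: in compound 1 the new methoxy sits ortho to a methoxy group and para to a large group, whereas in compound 4 it sits only para to a large group.

Within the data shown here, the only measured example of this change points to a weaker number, though its floor lies within the scatter. Compound 4 is therefore expected to sit near or somewhat above compound 3, with an estimated step of a 1.7-fold higher number from compound 3 to compound 4 (0.23 log units; within the scatter), resting on compound 2 to compound 1 giving an at least 1.7-fold higher number from compound 2 to compound 1 (0.25 log units; that floor lies within the scatter). For compound 4 the estimate in this assay is 1800 nM, between 600 nM and 5000 nM.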

Compound 4, half-maximal inhibitory concentration: 8040 nM
For compound 4 the middle estimate is 4.5-fold (0.65 log units) below the measured one; measured number above the stated range.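

In this assay, methoxy in place of hydrogen on an aromatic carbon gave a 7.5-fold higher number from compound 3 to compound 4 (0.88 log units; beyond the scatter), so on this core the change clearly goes with weaker inhibition. On the other core, an at least 1.7-fold higher number from compound 2 to compound 1 (0.25 log units; that floor lies within the scatter) gives only a floor, which means that the direction of the step may carry across but its size cannot be transferred, and the two steps cannot be ranked against each other: the same change on two cores in this assay, an at least 1.7-fold higher number (0.25 log units; that floor lies within the scatter) from compound 2 to compound 1 and a 7.5-fold higher number (0.88 log units; beyond the scatter) from compound 3 to compound 4; the limit leaves it open whether they differ. Compound 1 gives > 25000 nM, which is a limit of the assay and not a number, and this single value is what keeps the comparison open: the limit of > 25000 nM in this assay, at which 1 of the 4 values shown sits.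

With only two pairs, on two cores and with the new methoxy in differing surroundings, the compounds shown cannot separate an effect of the core from an effect of the place on the ring. As far as these compounds go, it remains open how a fluorine, an amine or a carboxylic acid would read in the place that methoxy takes in compound 4, and whether a longer chain such as ethoxy would follow the same direction there.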